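This account rests on a few compounds, and the source may have more. Where it says the series, first, only, none or still open, it means among the compounds named here.

In a functional assay on U-87MG ATCC cells for inhibition, with U-87 MG (Homo sapiens) as the target, read by MTT assay, with a stated time of 48 h (a lower number here means a stronger inhibitor, a higher number a weaker inhibitor), compound 1 (`COc1ccccc1-c1csc(N/N=C/c2ccc(F)c(F)c2)n1`) gives 40600 nM and stands at the upper end of the three numbers in hand. Compound 3 (`COc1cc(/C=N/Nc2nc(-c3cccc(Br)c3)cs2)c(Br)c(Br)c1OC`) gives 27600 nM and sits within the scatter of compound 1, whereas compound 2 (`COc1cc(/C=N/Nc2nc(-c3ccccc3)cs2)c(Br)c(Br)c1OC`) gives 20100 nM and lies lower than compound 1 by a gap just beyond the scatter.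

Compound 4 (`Fc1ccc(/C=N/Nc2nc(-c3ccccc3)cs2)cc1F`) has yet to be measured. Its difference from compound 1 is hydrogen in place of methoxy on an aromatic carbon and in words it is hydrogen in place of methoxy on an aromatic carbon, ortho to a large group, so that 2-methoxyphenyl becomes phenyl.

Within the data shown here, no measured step makes this exact swap. The nearest evidence is the step of a 1.4-fold higher number from compound 2 to compound 3 (0.14 log units; within the scatter) which concerns bromo in place of hydrogen on the same kind of ring, in a different remainder of the molecule, so it bears on the change only loosely. A small change on this ring therefore gives no reason to expect a large move in this assay and no step beyond the scatter is expected, with a slight lean towards a lower number. The expected step is a 1.4-fold lower number from compound 1 to compound 4 (0.13 log units; within the scatter) and this is only an estimate. In this assay the estimate for compound 4 is 30000 nM with an expected range from 14000 nM to 60000 nM as its upper end.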

Compound 4, half-maximal inhibitory concentration: > 100000 nM
Compound 4 ended at the assay's limit; the forecaster's own chance of this, stated with the estimate: 10%; at least 3.3-fold (0.52 log units) between middle value and limit.
By their numbers in this assay, from the lowest: compounds 2, 3 and 1 (each within the scatter of the next, the first and the last beyond it). At a limit, above all of these: compound 4.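

In this assay, compound 4 gives > 100000 nM, which is a limit of the assay and not a number. Hydrogen in place of methoxy, turning 2-methoxyphenyl into phenyl, gives an at least 2.4-fold higher number from compound 1 to compound 4 (0.39 log units; beyond the scatter), so among the compounds shown this is the first single change to move the read-out beyond the scatter, whereas the only earlier step, a 1.4-fold higher number from compound 2 to compound 3 (0.14 log units; within the scatter), concerned bromo in place of hydrogen and stayed within it. The new step can be read only as a lower bound on the true size of the change, because compound 4 sits at the end of the measurable range: the limit of > 100000 nM in this assay, at which 1 of the 4 values shown sits.

The compounds shown carry only methoxy or hydrogen at this place on the ring, so it remains open whether a hydroxyl, an ethoxy or an amine there would keep the number near that of compound 1 or push it to the limit as well. They also leave open whether the same exchange would give a step of similar size with the remainder of the molecule found in compound 2.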